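A few compounds are considered here, and "the series" means these few. Any claim that something is new, unique, unknown or untested is made for them only; others in the source may bear on it.

Compound 3 `Nc1nc(N)c(-c2ccc(NCc3ccnc(Cl)c3)cc2)c(COCc2ccccc2)n1` gives 1.5 nM in an in vitro assay on CHOK cells for displacement of a labelled ligand from growth hormone secretagogue receptor type 1 (Homo sapiens) (on this read-out higher numbers stand for weaker inhibition and lower numbers for stronger inhibition), and stands lowest among the three measured compounds; compound 1 `CCc1nc(N)nc(N)c1-c1ccc(NCc2ccc(C(C)=O)cc2)cc1` gives 57 nM and compound 2 `CCc1nc(N)nc(N)c1-c1ccc(NCc2ccnc(Cl)c2)cc1` gives 110 nM. Compound 4 `Nc1nc(N)c(-c2ccc(CNc3ccc([N+](=O)[O-])cc3)cc2)c(COCc2ccccc2)n1` differs from compound 3 by ((4-nitrophenyl)amino)methyl in place of ((2-chloropyridin-4-yl)methyl)amino on an aromatic carbon. The step that bears on this aryl exchange is a 1.9-fold higher number from compound 1 to compound 2 (0.29 log units; within the scatter), which was small, whereas a 73-fold lower number from compound 2 to compound 3 (1.87 log units; beyond the scatter) concerns another position and is not at issue here. Among the compounds with values here, no measured pair shows the reversed linker, so a modest weakening is expected, a 3.3-fold higher number from compound 3 to compound 4 (0.52 log units; beyond the scatter), with wide uncertainty. Compound 4 is therefore expected to give about 5 nM in this assay, within a range from 1 nM to 30 nM.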

Compound 4, half-maximal inhibitory concentration: 0.8 nM
Compound 4: the middle estimate sits 6.3-fold (0.80 log units) above what was measured; the whole stated range lies above it.
By their numbers in this assay, from the lowest: compounds 4 and 3 (each within the scatter of the next); then compounds 1 and 2 (each within the scatter of the next).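

With the benzyloxy group in place, this exchange on the aromatic carbon gives a 1.9-fold lower number from compound 3 to compound 4 (0.27 log units; within the scatter) in this assay. The earlier compounds shown here varied only the ring on an unchanged linker, whereas here the linker direction and the ring change together and the number still stays within the scatter. The data shown offer no reason for this tolerance. The two changes come together, so the compounds shown leave open what each does alone. Also open, from the compounds shown here alone, is how an amide linker, or a carboxylic acid in place of the nitro group, would read here.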